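The compounds below may be only part of what the source reports. "The series", "measured", "known", "first", "only" and "open" are said of these compounds alone.

Within the data shown here, in an ADME assay on BAEC cells (Bos taurus) for cytotoxicity, read by MTT assay, with a stated time of 2 days (a lower number here means a stronger inhibitor, a higher number a weaker inhibitor), compound 1 `COC(=O)COc1c(C=O)cc(Br)c(OC)c1Br` gives 151000 nM, the higher of the two numbers measured so far, and compound 2 `COc1c(Br)cc(C=O)c(OC(C)=O)c1Br` gives 23000 nM. Compound 3 `COC(=O)COc1c(CO)cc(Br)c(OC)c1Br` keeps the core of compound 1 but carries hydroxymethyl in place of formyl on an aromatic carbon, ortho to a (methoxycarbonyl)methoxy group: hydroxymethyl in place of formyl on an aromatic carbon. Among the measured compounds shown here, the only measured step, a 6.6-fold lower number from compound 1 to compound 2 (0.82 log units; beyond the scatter), is modest and comes from a change elsewhere, acetyl in place of (methoxycarbonyl)methyl on an oxygen on an aromatic ring. Formyl stays in place across that step, so the data give no direction for the present change and only a rough idea of size. A change no larger than that step is expected, most likely none beyond the scatter. The estimated step is a 1.3-fold lower number from compound 1 to compound 3 (0.10 log units; within the scatter). Compound 3 is expected at 120000 nM, with an estimated range of 40000 nM to 350000 nM.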

Compound 3, half-maximal inhibitory concentration: > 26000 nM
Compound 3 was reported as a limit; the forecaster's own chance of this, stated with the estimate: 15%; the middle value lies beyond the limit too.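

In this assay compound 3 gives > 26000 nM, which is a limit and not a number. Among these compounds, no step from compound 1 to compound 3 can be read from it. The compounds shown leave open both the direction and the size of the effect of hydroxymethyl in place of formyl on an aromatic carbon in this assay.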